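The source may hold more compounds than are shown below. What is called first, only, known or untested is meant among the compounds shown, and "the series" means these compounds.

Measured compounds in a functional assay on HCT-116 cells (Homo sapiens) for antiproliferative activity, read by MTT assay, with a stated time of 72 h; on this read-out higher numbers stand for weaker inhibition and lower numbers for stronger inhibition:
Compound 1, `O=C(O)CCc1cccc2c1B(O)OC2`: > 100000 nM, a limit of the assay.
Compound 2, `O=C(CCc1cccc2c1B(O)OC2)NC1CCCCC1`: > 100000 nM, also a limit of the assay.

Both values are limits, so in this assay compound 2 stands at the limit of > 100000 nM in this assay, at which 2 of the 2 values shown sit, with no number to place it against. Within the data shown here, the one measured step, a step that the two limits leave unreadable from compound 1 to compound 2, is unreadable, both of its ends being limits.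

Compound 3, `O=C(CCc1cccc2c1B(O)OC2)Nc1ccc(F)cc1`, carries the change (4-fluorophenyl in place of cyclohexyl on an amide-type nitrogen). Among the measured compounds shown here, no measured step bears on this change; the only step known is unreadable, so there is nothing from which a direction could be taken.

Compound 2 shows > 100000 nM, a limit. On that basis the step that the limit leaves unreadable from compound 2 to compound 3 is expected to be none beyond the scatter, with this assay most likely to report a limit again for compound 3 rather than a number. Compound 3 is estimated at 150000 nM, with a range from 40000 nM to 600000 nM.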

Compound 3, half-maximal inhibitory concentration: 650 nM
Compound 3: middle estimate off by 230-fold (2.36 log units), on the high side; measured number outside the range, below it.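

The change from cyclohexyl to 4-fluorophenyl on the amide-type nitrogen gives an at least 150-fold lower number from compound 2 to compound 3 (2.18 log units; beyond the scatter), so in this assay this position can carry activity on the shared core, which the earlier pair could not show, its step being unreadable. The aromatic ring and the fluorine enter together, so this one step does not assign the change to either of them. Compound 2 remains a limit, so the step has a lower bound only: the limit of > 100000 nM in this assay, at which 2 of the 3 values shown sit.

A plain phenyl on the same nitrogen would separate the contribution of the ring from that of the fluorine, and a 4-chlorophenyl or 4-methoxyphenyl would test how far the fluorine can be exchanged. A longer chain in place of the one carrying the carbonyl is still an open question for the amide of compound 3.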